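Naphthamide piperidines: moving a methyl around the benzyl ring

The compounds below may be only part of what the source reports. "The series", "measured", "known", "first", "only" and "open" are said of these compounds alone.

Measured compounds:
compound 1 `O=C(NC1CCN(Cc2ccc(Br)cc2)CC1)c1cccc2ccccc12`, 44 nM
compound 2 `O=C(NC1CCN(Cc2ccc(C(F)(F)F)cc2)CC1)c1cccc2ccccc12`, 96 nM
compound 3 `Cc1ccccc1CN1CCC(NC(=O)c2cccc3ccccc23)CC1`, 155 nM

In an assay on isolated protein for displacement of a labelled ligand from D(4) dopamine receptor (Homo sapiens) (on this read-out higher numbers stand for weaker inhibition and lower numbers for stronger inhibition), compound 3 holds the highest number of the three. One step is a 3.5-fold higher number from compound 1 to compound 3 (0.55 log units; beyond the scatter), whereas the other, a 1.6-fold higher number from compound 2 to compound 3 (0.21 log units; within the scatter), stays within the scatter. Compound 4 `Cc1ccc(CN2CCC(NC(=O)c3cccc4ccccc34)CC2)cc1` differs from compound 3 in one place: 4-methylphenyl in place of 2-methylphenyl on a saturated chain carbon bound to an amine nitrogen in a ring. Among the measured compounds shown here, no measured step changes the methyl alone, but compounds 1 and 2 carry 4-bromophenyl and 4-(trifluoromethyl)phenyl at the same place and both give lower numbers than compound 3 with its 2-methylphenyl. Those steps were modest, a 3.5-fold higher number from compound 1 to compound 3 (0.55 log units; beyond the scatter) and a 1.6-fold higher number from compound 2 to compound 3 (0.21 log units; within the scatter), so a modest move downward in this assay is expected for compound 4, with the caution that neither step isolates the methyl. The expected step from compound 3 to compound 4 is a 2.1-fold lower number from compound 3 to compound 4 (0.32 log units; beyond the scatter). Compound 4 is therefore estimated at 75 nM, within a range from 30 nM to 190 nM.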

Compound 4, inhibition constant: 69 nM
Compound 4: middle estimate off by 1.1-fold (0.04 log units), on the high side, within the range that was stated.
By their numbers in this assay, from the lowest: compounds 1, 4, 2 and 3 (each within the scatter of the next, the first and the last beyond it).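

Among the compounds shown here, compound 4 and compound 3 hold the same atoms, so in this assay the shift from 2-methylbenzyl to 4-methylbenzyl, a 2.2-fold lower number from compound 3 to compound 4 (0.35 log units; beyond the scatter), is the first step that isolates where the methyl sits, and it lies beyond the scatter. With the methyl in 4-methylphenyl, the swaps read a 1.4-fold lower number from compound 2 to compound 4 (0.14 log units; within the scatter) and a 1.6-fold higher number from compound 1 to compound 4 (0.20 log units; within the scatter), both within the scatter, so methyl cannot be told apart from trifluoromethyl or from bromo on this aromatic carbon. Nothing available explains why the placement of the methyl changes the number.

Going by these compounds, it remains open whether 2-bromophenyl or 2-(trifluoromethyl)phenyl would give numbers like that of 2-methylphenyl. Also open, on these data alone, is how a methoxy group, a nitrile or a carboxylic acid in place of the methyl would read in this assay, or a longer chain in place of the saturated chain carbon.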